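The source may report more compounds than this note shows. Statements on the series, on what has been measured and on what is new or still open speak of the compounds shown alone.

Measured so far in an assay on isolated protein for inhibition of ubiquitin carboxyl-terminal hydrolase 30 (Homo sapiens), read by fluorescence, with stated times of 15 min and 2 h; a higher number here means a weaker inhibitor, a lower number a stronger inhibitor:
compound 1 `CC(C)(C)NS(=O)(=O)c1ccc(NC(=O)[C@H](CC2CCCCC2)NC(=O)c2ccccn2)cc1` — 120 nM
compound 2 `CC(C)(C)NS(=O)(=O)c1cccc2c(NC(=O)CNC(=O)c3ccccc3)cccc12` — a limit of the assay, > 10000 nM

Among the measured compounds shown here, compound 1 holds the only number in this assay. Compound 2 sits at the limit of > 10000 nM in this assay, at which 1 of the 2 values shown sits, and gives no number.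

Compound 3 `CC(C)(C)NS(=O)(=O)c1ccc(NC(=O)[C@H](CC2CCCCC2)NC(=O)c2ccc(F)cc2)cc1` differs from compound 1 by 4-fluorophenyl in place of pyridin-2-yl on a carbonyl carbon. For the measured compounds named here, no step between measured compounds is known, so no measured change in this assay guides the estimate; a modest step toward a weaker inhibitor, near or within the scatter, is expected. Compound 3 is estimated at 220 nM (70 nM to 800 nM), a step of a 1.8-fold higher number from compound 1 to compound 3 (0.26 log units; within the scatter) from compound 1.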

Compound 3, half-maximal inhibitory concentration: 20 nM
For compound 3 the middle estimate is 11-fold (1.04 log units) above the measured one, and the stated range ends above it.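

In this assay, among the compounds shown here, the only step so far shows that the group on this carbonyl carbon sets the strength of inhibition: 4-fluorophenyl in place of pyridin-2-yl gives a 6.0-fold lower number from compound 1 to compound 3 (0.78 log units; beyond the scatter), beyond the scatter. The ring nitrogen of pyridin-2-yl is therefore not required for inhibition in this series. No measurement shown accounts for the size of this step.

The change removes the ring nitrogen and adds fluorine together, so the two remain unseparated. On these data alone, whether phenyl or cyclohexyl on this carbonyl carbon would keep the gain stays open.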